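This account rests on a few compounds, and the source may have more. Where it says the series, first, only, none or still open, it means among the compounds named here.

Four compounds share a rigid polycyclic core that carries a triazole bearing a phenyl ring. Compound 1 `C=C1C[C@]23C[C@@]1(O)CC[C@H]2c1ccc(O)c(C)c1[C@@H]3Cn1cc(-c2ccccc2)nn1` and compound 2 `C=C1C[C@]23C[C@@]1(O)CC[C@@H]2c1cccc(C)c1[C@@H]3Cn1cc(-c2ccccc2)nn1` differ in that core, and the difference between the two cores is not broken down here. Compound 3 `C=C1C[C@]23C[C@@]1(O)CC[C@H]2c1ccc(O)c(C)c1[C@@H]3Cn1cc(-c2ccc(F)cc2)nn1` is compound 1 with a change described as fluoro in place of hydrogen on an aromatic carbon, and compound 4 `C=C1C[C@]23C[C@@]1(O)CC[C@@H]2c1cccc(C)c1[C@@H]3Cn1cc(-c2ccc(F)cc2)nn1`, not yet measured, is compound 2 with the change (fluoro in place of hydrogen on an aromatic carbon), the same change made on the other core.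

In a functional assay on HL-60 cells (Homo sapiens) for cytotoxicity, read by MTT assay, with a stated time of 4 days (a lower number here means a stronger inhibitor, a higher number a weaker inhibitor), compound 1 gives > 20000 nM, which is a limit of the assay rather than a number. In this assay compound 2 likewise gives only a limit, > 20000 nM. In this assay compound 3 also gives a limit, > 20000 nM. The step that the two limits leave unreadable from compound 1 to compound 3 therefore cannot be read, since both ends sit at the limit of > 20000 nM in this assay, at which 3 of the 3 values shown sit.

For compound 4 the expectation is the same: a step that the limit leaves unreadable from compound 2 to compound 4 is expected, resting on compound 2 sitting at its limit > 20000 nM. Compound 4 is thus estimated at 30000 nM, between 15000 nM and 100000 nM.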

Compound 4, half-maximal inhibitory concentration: > 20000 nM
Compound 4: only a limit was reported (the forecaster's own chance of this, stated with the estimate: 90%); the middle value does not contradict the limit.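

The step from phenyl to 4-fluorophenyl between compound 2 and compound 4 cannot be read, since both compounds give only a limit of the assay and not a number: the limit of > 20000 nM in this assay, at which 4 of the 4 values shown sit.

The compounds shown leave open how strongly any of them acts in this assay and whether the fluoro changes that on either core.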